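A few compounds are considered here, and "the series" means these few. Any claim that something is new, unique, unknown or untested is made for them only; others in the source may bear on it.

Three members of the series carry a methylamide and a cyclopropylamide on a shared core and differ only in the group attached to the saturated chain carbon bound to the aromatic nitrogen. Compound 1 `CNC(=O)c1cc(C(=O)NC2CC2)cn(Cc2cccc(OC)c2)c1=O` gives 3 in a physicochemical assay for lipophilicity, at pH 7.4; on this read-out higher numbers stand for higher lipophilicity and lower numbers for lower lipophilicity. Compound 2 `CNC(=O)c1cc(C(=O)NC2CC2)cn(Cc2ccc(C)cc2)c1=O` gives 3.5 in this assay, and compound 3 `CNC(=O)c1cc(C(=O)NC2CC2)cn(Cc2cccc(C)c2)c1=O` gives 3.6 in this assay. Compound 3 holds the highest of the three numbers; its gap to compound 2 is within the scatter, while against compound 1 it stands a number 0.60 log units higher from compound 1 to compound 3 (beyond the scatter). The step of a number 0.50 log units higher from compound 1 to compound 2 (beyond the scatter) and the step of a number 0.10 log units higher from compound 2 to compound 3 (within the scatter) together show that moving the methyl around the ring changes little, whereas the exchange of methoxy for methyl carries the whole difference.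

Compound 4 `CNC(=O)c1cc(C(=O)NC2CC2)cn(Cc2cccc3occc23)c1=O` is not yet measured. Its change from compound 3 is 1-benzofuran-4-yl in place of 3-methylphenyl on a saturated chain carbon bound to an aromatic nitrogen. Within the data shown here, no measured step exchanges a phenyl bearing a single methyl for a group made of one five-membered aromatic ring with 1 hetero atom fused to one six-membered aromatic ring of carbon only, so the comparisons above guide only loosely. The measured steps give no reason to expect a shift beyond the scatter in this assay, and the step of a number 0.10 log units lower from compound 3 to compound 4 (within the scatter) is the estimated outcome. For compound 4 the expected value in this assay is 3.5, with a range from 3.1 to 3.9.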

Compound 4, distribution coefficient: 3.4
Estimate against measurement, compound 4: 0.10 log units above; low and high end bracket the measured number.
By their numbers in this assay, from the lowest: compound 1; then compounds 4, 2 and 3 (each within the scatter of the next).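

On the saturated chain carbon bound to an aromatic nitrogen, 1-benzofuran-4-yl brings a five-membered aromatic ring with 1 hetero atom, 9 heavy atoms against 7 and 1 hydrogen-bond acceptor against 0 for 3-methylphenyl, yet in this assay it stays within the scatter of both methylphenyl compounds (a number 0.20 log units lower from compound 3 to compound 4 (within the scatter); a number 0.10 log units lower from compound 2 to compound 4 (within the scatter)). The oxygen of the entering group does not place the new compound with the 3-methoxyphenyl compound (a number 0.40 log units higher from compound 1 to compound 4 (beyond the scatter)), so compound 1 now stands alone at the low end of the four, with its steps to all three others beyond the scatter. No supporting data accompany these numbers to account for the pattern.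

Across the four compounds, the group at this position is always an aromatic ring system on a single saturated carbon, so the response of this assay to an amine or a carboxylic acid on that ring, or to a longer chain in place of that carbon, remains open. The methylamide and the cyclopropylamide are shared by all four compounds, which leaves the contribution of either group to these numbers unread.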